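From 2,5-dichlorophenyl to 3-chloro-5-fluorophenyl on the sulfonamide

This account rests on a few compounds, and the source may have more. Where it says the series, first, only, none or still open, it means among the compounds named here.

In a functional assay on cells (leukaemia cell line, Homo sapiens) for inhibition, read by sulforhodamine B assay, with a stated time of 48 h (a lower number here means a stronger inhibitor of growth, a higher number a weaker inhibitor of growth), compound 1 `O=S(=O)(Nc1ccc(Cl)cc1Cl)c1ccc(-c2cnc(C3CC3)o2)cc1` gives 481 nM and compound 2 `O=S(=O)(Nc1ccccc1Cl)c1ccc(-c2cnc(C3CC3)o2)cc1` gives 429 nM. Compound 3 `O=S(=O)(Nc1cc(Cl)ccc1Cl)c1ccc(-c2cnc(C3CC3)o2)cc1` gives 1020 nM, the highest of the three numbers. The next compound, compound 4 `O=S(=O)(Nc1cc(F)cc(Cl)c1)c1ccc(-c2cnc(C3CC3)o2)cc1`, differs from it as follows: 3-chloro-5-fluorophenyl in place of 2,5-dichlorophenyl on a sulfonamide nitrogen. This puts 3-chloro-5-fluorophenyl in place of 2,5-dichlorophenyl on a sulfonamide nitrogen.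

For the measured compounds named here, three measured steps bear on this change. The step of a 1.1-fold lower number from compound 1 to compound 2 (0.05 log units; within the scatter) shows that the two lower values stay within the scatter of each other. The steps of a 2.1-fold higher number from compound 1 to compound 3 (0.33 log units; beyond the scatter) and a 2.4-fold higher number from compound 2 to compound 3 (0.38 log units; beyond the scatter) are both modest, and both lead to the 2,5-dichlorophenyl group of compound 3. Compound 4 gives up that group, which suggests a partial return towards the lower values. However, no measured compound carries fluoro, so the size of the move remains uncertain.

The expected change is modest and towards a lower number, with an estimated 1.6-fold lower number from compound 3 to compound 4 (0.20 log units; within the scatter). The estimate for compound 4 is 650 nM, with an expected range of 280 nM to 1400 nM.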

Compound 4, concentration for 50% growth inhibition: 1440 nM
Beside the measured number, compound 4's estimate is 2.2-fold (0.35 log units) below it; measured number outside the range, above it.
By their numbers in this assay, from the lowest: compounds 2 and 1 (each within the scatter of the next); then compounds 3 and 4 (each within the scatter of the next).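

In this assay, the change to 3-chloro-5-fluorophenyl on the sulfonamide nitrogen gives a 1.4-fold higher number from compound 3 to compound 4 (0.15 log units; within the scatter), so the lower values do not return once 2,5-dichlorophenyl is gone. Compound 4 instead stands with compound 3 and apart from the other two, with a 3.4-fold higher number from compound 2 to compound 4 (0.53 log units; beyond the scatter) and a 3.0-fold higher number from compound 1 to compound 4 (0.48 log units; beyond the scatter), both modest steps, which shows that the higher numbers at this position are not tied to 2,5-dichlorophenyl alone. Nothing measured here gives a reason for these differences.

The compounds shown leave open what fluoro and chloro each contribute within 3-chloro-5-fluorophenyl, as a simple 3-fluorophenyl or 3-chlorophenyl group would help to show. They also leave open how this assay would respond to a methoxy group or a carboxylic acid on the same ring.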